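The compounds below may be only part of what the source reports. "The series", "measured", "known", "first", "only" and "open" are said of these compounds alone.

Among the measured compounds shown here, compound 1, with the structure `C=CCn1c(=O)/c(=C\c2cc(F)ccc2C)[nH]c(=O)/c1=C\c1ccccc1OC`, is the only member of this small set that returns a number: in a functional assay on MOLT-4 cells (Homo sapiens) for cytotoxicity, read by CCK-8 assay, with a stated time of 72 h (a lower number here means a stronger inhibitor, a higher number a weaker inhibitor), compound 1 gives 3800 nM. Compound 2, with the structure `C=CCn1c(=O)/c(=C\c2ccc(C)cc2)[nH]c(=O)/c1=C\c1ccccc1OC`, carries a 4-methylphenyl group where compound 1 carries a 5-fluoro-2-methylphenyl group, and in this assay compound 2 is recorded as "not active" (no number reported), so no single number marks where compound 2 stands; it sits at the weak end of what the two measured compounds show, while compound 1 has the only measurable inhibition.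

Compound 3, with the structure `C=CCn1c(=O)/c(=C\c2ccc(Cl)c(Cl)c2)[nH]c(=O)/c1=C\c1ccccc1OC`, is the next compound to be tested in this assay. It differs from compound 2 in one place: 3,4-dichlorophenyl in place of 4-methylphenyl on a double-bonded chain carbon bound to an aromatic carbon. For the measured compounds named here, no measured pair in this set isolates such a change, so its size is not known from the data. Since compound 2 gives no number, any recovery of a measurable value in compound 3 would count as a move toward stronger inhibition, though a second inactive result remains possible.

Compound 3 is expected to give about 6000 nM in this assay, with the estimate spanning 1500 nM to 30000 nM.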

Compound 3, half-maximal inhibitory concentration: "not active" (no number reported)
Compound 3 has no reported number here, and the estimate cannot be compared.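

Compound 2 and compound 3 are both recorded as not active in this assay with no number reported, so no step can be read between them. Nothing shown here offers an explanation for this result. The compounds shown leave open how much replacing 4-methylphenyl with 3,4-dichlorophenyl changes inhibition in this cell assay.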